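The compounds below may be only part of what the source reports. "The series", "measured", "known", "first", "only" and "open" are said of these compounds alone.

In a functional assay on NCI-H460 cells (Homo sapiens) for cytotoxicity, read by MTT assay, with a stated time of 3 days (on this read-out higher numbers stand for weaker inhibition and lower numbers for stronger inhibition), three compounds sharing one core have been measured, and they differ only in the group on a nitrogen on an aromatic ring. Compound 1 `N#Cc1c(NN)nc(SCc2nc3ccccc3[nH]2)nc1-c1ccccc1`, with amino there, gives 2.6 nM. Compound 2 `N#Cc1c(Nc2ccccc2)nc(SCc2nc3ccccc3[nH]2)nc1-c1ccccc1`, with phenyl, gives 4.54 nM. Compound 3 `CNc1nc(SCc2nc3ccccc3[nH]2)nc(-c2ccccc2)c1C#N`, with methyl, gives 3.2 nM. Compound 3 therefore lies within the scatter of both others, and the three values do not separate.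

Compound 4 `N#Cc1c(Nc2nccs2)nc(SCc2nc3ccccc3[nH]2)nc1-c1ccccc1` keeps the core and changes that one place: 1,3-thiazol-2-yl in place of methyl on a nitrogen on an aromatic ring. In words, it has 1,3-thiazol-2-yl in place of methyl on a nitrogen on an aromatic ring. Two measured steps at this place, a 1.7-fold higher number from compound 1 to compound 2 (0.24 log units; within the scatter) and a 1.2-fold higher number from compound 1 to compound 3 (0.09 log units; within the scatter), stay within the scatter. Within the data shown here, the closest precedent is compound 2, which carries a ring at this place, and its exchange with methyl is a 1.4-fold lower number from compound 2 to compound 3 (0.15 log units; within the scatter), again within the scatter. Among the measured compounds shown here, no compound with a hetero atom in that ring has been measured, so the precedent is only partial. On this basis, no step beyond the scatter is expected, and the estimated step is a 1.4-fold higher number from compound 3 to compound 4 (0.15 log units; within the scatter). The estimate for compound 4 is 4.5 nM, with an expected range from 1.8 nM to 12 nM.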

Compound 4, half-maximal inhibitory concentration: 3.37 nM
Compound 4: middle estimate off by 1.3-fold (0.13 log units), on the high side; the measured number falls inside the stated range.
By their numbers in this assay, from the lowest: compounds 1, 3, 4 and 2 (each within the scatter of the next).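

In this assay, the step of a 1.1-fold higher number from compound 3 to compound 4 (0.02 log units; within the scatter) shows that a ring with hetero atoms can stand on this nitrogen without moving the number beyond the scatter, which the earlier phenyl compound could only suggest. Among these compounds, the comparisons with the other two groups agree, with a 1.3-fold lower number from compound 2 to compound 4 (0.13 log units; within the scatter) on the exchange with phenyl and a 1.3-fold higher number from compound 1 to compound 4 (0.11 log units; within the scatter) on the exchange with amino, so amino, methyl, phenyl and 1,3-thiazol-2-yl do not separate across these four compounds, and no compound among them goes against this. No available evidence explains this lack of separation.

These compounds leave open whether the same holds for a longer chain ending in a carboxylic acid or an amine, or for an acetyl group on this nitrogen, since every group shown here is either a single small substituent or one aromatic ring. They also leave open whether any change at this place can produce a step beyond the scatter, and the four values alone cannot show how far this tolerance extends.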